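A few compounds are considered here, and "the series" means these few. Any claim that something is new, unique, unknown or untested is made for them only; others in the source may bear on it.

Measured compounds in a functional assay on MKN-45 cells (Homo sapiens) for cytotoxicity, read by MTT assay, with a stated time of 72 h; a lower number here means a stronger inhibitor, a higher number a weaker inhibitor:
compound 1 `COc1cc2c(Oc3ccc(NC(=O)c4nccc(-c5ccc(F)cc5)n4)cc3F)ccnc2cc1OCCCN1CCCCC1` gives 930 nM
compound 2 `COc1cc2c(Oc3ccc(NC(=O)c4nccc(-c5ccc(F)cc5)n4)cc3F)ccnc2cc1OCCCN1CCN(C)CC1` gives 90 nM
compound 3 `COc1cc2c(Oc3ccc(NC(=O)c4nccc(-c5ccc(C)cc5)n4)cc3F)ccnc2cc1OCCCN1CCCC1` gives 240 nM

Compound 3 stands second highest of the three numbers. Compound 2 lies nearest to it, with a lower number, and compound 1 furthest, with a higher number; both gaps are beyond the scatter. Within the data shown here, the one step measured, a 10-fold lower number from compound 1 to compound 2 (1.01 log units; beyond the scatter), concerns the group on the saturated chain and is large. The step to compound 4 `COc1cc2c(Oc3ccc(NC(=O)c4nccc(-c5ccc(F)cc5)n4)cc3F)ccnc2cc1OCCCN1CCCC1` is a different change: fluoro in place of methyl on an aromatic carbon. Among the measured compounds shown here, no measured pair touches that aromatic position, so the step from compound 1 to compound 2 does not bear on it, and the data give no direction for it. The expected step is therefore none beyond the scatter, no change at the digits printed from compound 3 to compound 4 (within the scatter). Compound 4 is estimated at 240 nM in this assay, with a range from 100 nM to 600 nM that reflects the absence of any measured precedent for this change.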

Compound 4, half-maximal inhibitory concentration: 490 nM
For compound 4 the middle estimate is 2.0-fold (0.31 log units) below the measured one; the measured number falls inside the stated range.
By their numbers in this assay, from the lowest: compound 2; then compound 3; then compounds 4 and 1 (each within the scatter of the next).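

The aromatic carbon bearing the methyl or fluoro now has a measured step: in this assay, 4-methylphenyl to 4-fluorophenyl gives a 2.0-fold higher number from compound 3 to compound 4 (0.31 log units; beyond the scatter) as a modest change in the pyrrolidin-1-yl pair. With the 4-fluorophenyl group held constant, pyrrolidin-1-yl and piperidin-1-yl are not separated, at a 1.9-fold lower number from compound 1 to compound 4 (0.28 log units; within the scatter) and with that step inside the scatter, whereas 4-methylpiperazin-1-yl stands apart, with a 5.4-fold higher number from compound 2 to compound 4 (0.74 log units; beyond the scatter) on going to pyrrolidin-1-yl. No supporting evidence accounts for either difference.

As far as these compounds go, whether the methyl-to-fluoro step keeps its direction and size with piperidin-1-yl or 4-methylpiperazin-1-yl on the chain remains open. Also open, from the compounds shown here alone, is how chloro or methoxy at the same aromatic carbon, or morpholin-4-yl at the end of the chain, would read in this assay and compare with these compounds.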